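The source may hold more compounds than are shown below. What is called first, only, known or untested is meant among the compounds shown, and "the series" means these compounds.

Measured in a functional assay on CCRF-CEM cells (Homo sapiens) for antiproliferative activity; a lower number here means a stronger inhibitor, a higher number a weaker inhibitor:
compound 1 `COc1cc(C(=O)c2sc(-c3ccsc3)cc2N)cc(OC)c1OC` gives 9.6 nM
compound 2 `COc1ccc(-c2cc(N)c(C(=O)c3cc(OC)c(OC)c(OC)c3)s2)cc1` gives 19 nM

Among the compounds with values here, the single measured step (a 2.0-fold higher number from compound 1 to compound 2 (0.30 log units; within the scatter)) lies within the scatter, so compound 2 stands level with compound 1 on these numbers. Compound 3 `COc1cc(C(=O)c2sc(-c3ccc(C(F)(F)F)cc3)cc2N)cc(OC)c1OC` has trifluoromethyl in place of methoxy on an aromatic carbon, para to a large group (trifluoromethyl in place of methoxy on an aromatic carbon). That measured step is small, but none replaces methoxy alone, so the guide is weak. A modest rise in the number is expected in this assay, with wide uncertainty. Compound 3 is estimated at 60 nM, with an expected range from 15 nM to 300 nM in this estimate. The estimate means an expected change (a 3.2-fold higher number from compound 2 to compound 3 (0.50 log units; beyond the scatter)).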

Compound 3, half-maximal inhibitory concentration: 270 nM
For compound 3 the middle estimate is 4.5-fold (0.65 log units) below the measured one; measured number inside the range.
By their numbers in this assay, from the lowest: compounds 1 and 2 (each within the scatter of the next); then compound 3.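

In this assay this position proves sensitive to the substituent: 4-(trifluoromethyl)phenyl in place of 4-methoxyphenyl brings a 14-fold higher number from compound 2 to compound 3 (1.15 log units; beyond the scatter), whereas the earlier step between thiophen-3-yl and 4-methoxyphenyl stayed within the scatter. Set against the thiophen-3-yl group, the same 4-(trifluoromethyl)phenyl group brings a 28-fold higher number from compound 1 to compound 3 (1.45 log units; beyond the scatter). Nothing available explains this loss.

The compounds shown leave open whether the loss is particular to trifluoromethyl or extends to other replacements for methoxy. A hydroxy group, a methyl group or a chlorine atom at that place would help to settle this.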